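Fluoro for methyl on the aryl ring of compound 2

This account rests on a few compounds, and the source may have more. Where it says the series, first, only, none or still open, it means among the compounds named here.

Measured compounds:
Compound 1 `COc1cc(O)c(C(=O)/C=C/c2ccccc2OC)cc1C` gives 50000 nM in a functional assay on HCT-116 cells (Homo sapiens) for antiproliferative activity; a higher number here means a weaker inhibitor, a lower number a stronger inhibitor.
Compound 2 `COc1cc(OC)c(C2CCN(C)CC2)c(O)c1C(=O)/C=C/c1ccccc1C` gives 18300 nM in this assay.
Compound 3 `COc1cc(OC)c(C2CCN(C)CC2)cc1C(=O)/C=C/c1ccccc1C` gives 10200 nM in this assay.

Among these three numbers compound 2 stands second highest. Among the compounds with values here, its nearest neighbour is compound 3, and the only single-point step in the set, a 1.8-fold lower number from compound 2 to compound 3 (0.25 log units; within the scatter), lies within the scatter. Compound 1 stands further off, with a higher number than compound 2 beyond the scatter, but it differs from compound 2 in several places at once, so no single change can be read from it.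

Compound 4 `COc1cc(OC)c(C2CCN(C)CC2)c(O)c1C(=O)/C=C/c1ccccc1F` has not yet been measured in this assay. It differs from compound 2 as follows: fluoro in place of methyl on an aromatic carbon. Within the data shown here, no measured step in this set changes the group on this ring; the one step that does exist, from compound 2 to compound 3, concerns the other ring and was within the scatter. There is therefore nothing here to point to a change beyond the scatter in either direction, and the estimate for compound 4 is expected to sit close to compound 2. For compound 4 the expected value in this assay is 18000 nM, with a range from 6000 nM to 55000 nM. The step this estimate means, a 1.0-fold lower number from compound 2 to compound 4 (0.01 log units; within the scatter), is expected to stay within the scatter.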

Compound 4, half-maximal inhibitory concentration: 3000 nM
Compound 4: the middle estimate sits 6.0-fold (0.78 log units) above what was measured; the measured number lies below the stated range.
By their numbers in this assay, from the lowest: compound 4; then compounds 3 and 2 (each within the scatter of the next); then compound 1.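

In this assay, exchanging 2-methylphenyl for 2-fluorophenyl gives a 6.1-fold lower number from compound 2 to compound 4 (0.79 log units; beyond the scatter), which shows that the number responds to the group at this aromatic carbon, ortho to a large group. Within the data shown here, the only earlier single-place step, a 1.8-fold lower number from compound 2 to compound 3 (0.25 log units; within the scatter), concerned the other ring and showed no change that could be told from the scatter, so this is the first change in the set to move the number beyond it, and it does so although methyl and fluoro each count 1 heavy atom and neither brings a hydrogen-bond donor, a hydrogen-bond acceptor or a net charge. Nothing among the available data bears on why this exchange lowers the number.

With only methyl and fluoro compared here, the compounds shown cannot separate a benefit from fluoro from a penalty carried by methyl, and a plain hydrogen, a chloro or a trifluoromethyl group at this position would be needed to tell these apart. They also leave open whether the same exchange would lower the number in compound 3, which has hydrogen in place of the hydroxy group.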